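From 2,5-dimethylphenyl to 4-chlorophenyl on a sulfonyl sulfur

The compounds below may be only part of what the source reports. "The series", "measured", "known", "first", "only" and "open" are said of these compounds alone.

In an ADME assay on HEK-293T cells (Homo sapiens) for cytotoxicity, read by MTT assay, with a stated time of 24 h (a higher number here means that more compound is tolerated, a lower number that less compound is tolerated), compound 3 (`Cc1ccc(C)c(S(=O)(=O)n2c(-c3cn(-c4ccccc4)nc3-c3ccc(C(F)(F)F)cc3)nc3ccccc32)c1`) gives 223000 nM. Compound 1 (`Cc1ccc(-c2nn(-c3ccccc3)cc2-c2nc3ccccc3n2S(=O)(=O)c2ccc(Cl)cc2)cc1`) gives 167000 nM, which lies within the scatter of the value for compound 3, so these two numbers cannot be ranked. Compound 2 (`COc1ccc(S(=O)(=O)n2c(-c3cn(-c4ccccc4)nc3-c3ccc(C(F)(F)F)cc3)nc3ccccc32)cc1`) reads > 300000 nM, which is a limit of the assay and not a number.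

The next structure, compound 4 (`O=S(=O)(c1ccc(Cl)cc1)n1c(-c2cn(-c3ccccc3)nc2-c2ccc(C(F)(F)F)cc2)nc2ccccc21`), has 4-chlorophenyl in place of 2,5-dimethylphenyl on a sulfonyl sulfur.

Two pieces of evidence bear on this change. Among the compounds with values here, the only measured step at this place, with 2,5-dimethylphenyl in place of 4-methoxyphenyl, is an at least 1.3-fold lower number from compound 2 to compound 3 (0.12 log units; that floor lies within the scatter). It therefore shows no change beyond the scatter. Compound 1 also carries 4-chlorophenyl on a sulfonyl sulfur, and its 167000 nM shows that this group can occur with a number close to that of compound 3, although the rest of compound 1 is not the same.

On this evidence, no shift beyond the scatter is expected in this assay. The estimate is a 1.1-fold lower number from compound 3 to compound 4 (0.05 log units; within the scatter), a step too small to stand out from repeat measurements. Compound 4 is expected at about 200000 nM, with an estimated range of 120000 nM to 300000 nM.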

Compound 4, half-maximal cytotoxic concentration: 75300 nM
Compound 4: the middle estimate sits 2.7-fold (0.42 log units) above what was measured, outside the stated range (below it).
By their numbers in this assay, from the lowest: compound 4; then compounds 1 and 3 (each within the scatter of the next). At a limit, above all of these: compound 2.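

In this assay, the group on the sulfonyl sulfur turns out to matter, which the earlier step at this place could not show: swapping 2,5-dimethylphenyl for 4-chlorophenyl gives a 3.0-fold lower number from compound 3 to compound 4 (0.47 log units; beyond the scatter). Two further steps show that the number depends on more than one part of the molecule: chloro in place of methoxy on an aromatic carbon gives an at least 3.9-fold lower number from compound 2 to compound 4 (0.60 log units; beyond the scatter), and trifluoromethyl in place of methyl on an aromatic carbon, with 4-chlorophenyl kept on the sulfonyl sulfur, gives a 2.2-fold lower number from compound 1 to compound 4 (0.35 log units; beyond the scatter). The reading for compound 2 is a limit of the assay and not a number, so the step from it gives only a floor: the limit of > 300000 nM in this assay, at which 1 of the 4 values shown sits.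

The compounds shown leave open whether the lower number in compound 4 follows from the arrival of the chlorine or the loss of the two methyl groups, since a plain phenyl group on the sulfonyl sulfur does not appear among them. They also leave open how this assay would read with an amine or a carboxylic acid on that aromatic ring.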